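Swapping benzyl for pyridin-2-yl on the piperazine ring

A few compounds are considered here, and "the series" means these few. Any claim that something is new, unique, unknown or untested is made for them only; others in the source may bear on it.

Measured compounds: compound 1 `O=C(Nc1ccccc1)Nc1nc(NC2CC2)cc(Sc2c[nH]c3ccccc23)n1` gives 14300 nM in a functional assay on HepG2 cells (Homo sapiens) for inhibition, with a stated time of 72 h; on this read-out higher numbers stand for weaker inhibition and lower numbers for stronger inhibition; compound 2 `O=C(Nc1ccccc1)Nc1nc(Sc2c[nH]c3ccccc23)cc(N2CCCC2)n1` gives 11400 nM; compound 3 `O=C(Nc1ccccc1)Nc1nc(Sc2c[nH]c3ccccc23)cc(N2CCN(Cc3ccccc3)CC2)n1` gives 8160 nM.

Compound 3 stands alongside compound 2 and compound 1, all three numbers within the usual scatter of one another. Compound 4 `O=C(Nc1ccccc1)Nc1nc(Sc2c[nH]c3ccccc23)cc(N2CCN(c3ccccn3)CC2)n1` differs from compound 3 by pyridin-2-yl in place of benzyl on an amine nitrogen in a ring. Among the compounds with values here, no measured step touches this position. Within the data shown here, the one measured step, a 1.3-fold lower number from compound 1 to compound 2 (0.10 log units; within the scatter), changed the amine at the same aromatic carbon without moving the number beyond scatter; compound 2 and compound 3 likewise sit close together. Compound 4 is therefore expected to show no step beyond scatter, a 1.0-fold lower number from compound 3 to compound 4 (0.01 log units; within the scatter), and is estimated at 8000 nM, between 3500 nM and 18000 nM.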

Compound 4, half-maximal inhibitory concentration: 8930 nM
For compound 4 the middle estimate is 1.1-fold (0.05 log units) below the measured one; low and high end bracket the measured number.
By their numbers in this assay, from the lowest: compounds 3, 4, 2 and 1 (each within the scatter of the next).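

In this assay, pyridin-2-yl in place of benzyl on an amine nitrogen in a ring gives a 1.1-fold higher number from compound 3 to compound 4 (0.04 log units; within the scatter), so this first direct test of the position shows no change beyond the scatter, although the entering ring carries a hydrogen-bond acceptor. Putting 4-(pyridin-2-yl)piperazin-1-yl on the aromatic carbon instead of pyrrolidin-1-yl gives a 1.3-fold lower number from compound 2 to compound 4 (0.11 log units; within the scatter), and instead of cyclopropylamino gives a 1.6-fold lower number from compound 1 to compound 4 (0.20 log units; within the scatter). No supporting measurement bears on these results. On these data alone, whether a carboxylic acid or a longer chain carrying an amine on this ring nitrogen would move the number beyond the scatter remains open.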